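A few compounds are considered here, and "the series" means these few. Any claim that something is new, unique, unknown or untested is made for them only; others in the source may bear on it.

Measured compounds:
- compound 1 `O[C@@H]1CO[C@@H](Oc2ccc3ccccc3c2)C[C@H]1O`: 228 uM
- compound 2 `O[C@H]1[C@H](Oc2ccc3ccccc3c2)OC[C@@H](O)[C@@H]1F`: 94 uM
- compound 3 `CO[C@@H]1CO[C@@H](Oc2ccc3ccccc3c2)[C@H](O)[C@H]1O`: 135 uM

In a functional assay on HCC70 cells (Homo sapiens) for antiproliferative activity, read by crystal violet staining, with a stated time of 96 h (on this read-out lower numbers stand for an effect already at smaller amounts and higher numbers for an effect only at larger amounts of compound), compound 2 gives 94 uM, the lowest of the three numbers recorded so far. The nearest neighbour is compound 3, which in this assay gives 135 uM, a gap that sits within the usual scatter, so the two cannot be ranked against each other. The furthest is compound 1, which in this assay gives 228 uM; that gap lies beyond the scatter, so compound 2 does stand apart from compound 1 on this read-out.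

Compound 4 `O[C@@H]1CO[C@@H](Oc2ccc3ccccc3c2)[C@H](O)C1` has not yet been measured in this assay. It differs from compound 2 in one place: hydrogen in place of fluoro on a saturated ring carbon. Among the compounds with values here, no step between measured compounds matches this change, so its size has to be guessed. The two fluorine-free compounds, compound 1 and compound 3, both give higher numbers than compound 2 in this assay, which argues for the number of compound 4 coming out somewhat higher, though by a margin that may not exceed the scatter.

The expected step in this assay from compound 2 to compound 4 is a 1.6-fold higher number from compound 2 to compound 4 (0.20 log units; within the scatter). Compound 4 is accordingly estimated at 150 uM in this assay, with a range from 70 uM to 320 uM.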

Compound 4, concentration for half-maximal effect: 179 uM
For compound 4 the middle estimate is 1.2-fold (0.08 log units) below the measured one; measured number inside the range.
By their numbers in this assay, from the lowest: compounds 2, 3, 4 and 1 (each within the scatter of the next, the first and the last beyond it).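

In this assay, within the data shown here, the first direct reading of hydrogen in place of fluoro on a saturated ring carbon is a 1.9-fold higher number from compound 2 to compound 4 (0.28 log units; within the scatter), so on this read-out compound 4 cannot be told apart from compound 2. The earlier compounds shown here offered no pair differing at this position alone; this pair shows that, on a saturated ring carbon next to two ring atoms that each bear a hydroxy group, losing the fluoro leaves the number within the scatter, and the fluoro cannot be credited with a measurable gain. No measurement in hand bears on what lies behind this step.

On these data alone, whether an amine, a carboxylic acid or a longer chain on this ring carbon would move the number beyond the scatter remains open, and so does the outcome with chloro or hydroxy at the same place. Among these compounds, also open is whether the exchange of fluoro for hydrogen reads the same on another core, since this single pair is the only one that carries the change.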